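Working notes: diethylamino for dimethylamino on the side chain

The compounds below may be only part of what the source reports. "The series", "measured", "known", "first", "only" and "open" are said of these compounds alone.

Compound 1 `CN(C)CCCn1c(N)c(-c2nc3ccccc3n2C)c2nc(C#N)c(C#N)nc21` and compound 2 `CCN(CC)CCCn1c(N)c(-c2nc3ccccc3n2C)c2nc(C#N)c(C#N)nc21` share one core; compound 3 `CN(C)CCCCn1c(N)c(-c2nc3cc(Cl)ccc3[nH]2)c2nc(C#N)c(C#N)nc21` and compound 4 `CCN(CC)CCCCn1c(N)c(-c2nc3cc(Cl)ccc3[nH]2)c2nc(C#N)c(C#N)nc21` share another, and the difference between the two cores is not broken down here. In a functional assay on HL60/MX2 cells (Homo sapiens) for antiproliferative activity, read by MTT assay, with a stated time of 48 h (on this read-out lower numbers stand for stronger inhibition and higher numbers for weaker inhibition), compound 1 gives 11300 nM and compound 2 gives 4470 nM; the change diethylamino in place of dimethylamino on a saturated chain carbon, three bonds along the chain from an aromatic nitrogen made a 2.5-fold lower number from compound 1 to compound 2 (0.40 log units; beyond the scatter). Going by the values given here, compound 3 gives 580 nM in this assay, the lowest number so far. Compound 4 carries the same kind of change, (diethylamino in place of dimethylamino on a saturated chain carbon, four bonds along the chain from an aromatic nitrogen), but on a saturated chain carbon four bonds along the chain from an aromatic nitrogen rather than three, and on the other core. Among the compounds with values here, only a single precedent exists, a 2.5-fold lower number from compound 1 to compound 2 (0.40 log units; beyond the scatter), which gives little to rest on. For compound 4 a step of similar size is expected, a 1.9-fold lower number from compound 3 to compound 4 (0.29 log units; within the scatter), resting on that precedent. Compound 4 is thus estimated at 300 nM, between 120 nM and 800 nM.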

Compound 4, half-maximal inhibitory concentration: 1770 nM
Compound 4: middle estimate off by 5.9-fold (0.77 log units), on the low side; the measured number lies above the stated range.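

In this assay, the diethylamino for dimethylamino change gives a 3.1-fold higher number from compound 3 to compound 4 (0.48 log units; beyond the scatter), so a gain seen on one core cannot be assumed on another in this series. Set beside the earlier step, the new one runs in the opposite direction: the same change on two cores in this assay, a 2.5-fold lower number (0.40 log units; beyond the scatter) from compound 1 to compound 2 and a 3.1-fold higher number (0.48 log units; beyond the scatter) from compound 3 to compound 4, 7.7-fold (0.89 log units) apart, beyond the scatter of two such steps. This does not show which difference governs the direction, since the two pairs differ both in the core and in whether the change sits three or four bonds along the chain from an aromatic nitrogen, and each case rests on a single pair.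

Open, going by these compounds, is whether the direction follows the core or the chain, which the shorter chain of compound 1 on the core of compound 3 would help separate. Also open, on these data alone, is how a cyclic amine such as pyrrolidine or morpholine would compare on either core.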